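Triazole aryl variation on the shared core

The source may hold more compounds than are shown below. What is called first, only, known or untested is meant among the compounds shown, and "the series" means these compounds.

Compound 1 `C=C1C[C@]23C[C@@]1(O)CC[C@H]2c1ccc(OS(=O)(=O)c2ccc(C)cc2)c(C)c1[C@@H]3Cn1cc(-c2ccc(Br)cc2)nn1` in a functional assay on MCF7 cells (Homo sapiens) for cytotoxicity, read by MTT assay, with a stated time of 4 days (a lower number here means a stronger inhibitor, a higher number a weaker inhibitor), gives > 20000 nM, which is a limit of the assay and not a number.
Compound 2 `C=C1C[C@]23C[C@@]1(O)CC[C@H]2c1ccc(O)c(C)c1[C@@H]3Cn1cc(-c2ccc(C(F)(F)F)cc2)nn1` in this assay gives 12400 nM.
Compound 3 `C=C1C[C@]23C[C@@]1(O)CC[C@H]2c1ccc(OS(=O)(=O)c2ccc(C)cc2)c(C)c1[C@@H]3Cn1cc(-c2ccccn2)nn1` in this assay gives > 20000 nM, again a limit rather than a number.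

Compound 3 thus stands at the limit, as does compound 1; only compound 2 returns a number, and compound 2 differs from compound 3 in two places, so its value stands on its own. Within the data shown here, the single measured step, a step that the two limits leave unreadable from compound 1 to compound 3, runs between two limits and its size cannot be read; the limit of > 20000 nM in this assay, at which 2 of the 3 values shown sit, is all the series gives on this side.

Compound 4 `C=C1C[C@]23C[C@@]1(O)CC[C@H]2c1ccc(OS(=O)(=O)c2ccc(C)cc2)c(C)c1[C@@H]3Cn1cc(-c2ccc(C(F)(F)F)cc2)nn1` differs from compound 3 as 4-(trifluoromethyl)phenyl in place of pyridin-2-yl on an aromatic carbon. Among the measured compounds shown here, the only step that touches the same aromatic carbon is the one from compound 1 to compound 3, and it is unreadable, so no size of step can be drawn from it; the expectation for this assay is therefore that compound 4 remains at or near the limit, with a step that the limit leaves unreadable from compound 3 to compound 4 that is not expected to rise above the scatter. Compound 4 is estimated at 25000 nM, within 10000 nM to 60000 nM, most likely reported only as a limit.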

Compound 4, half-maximal inhibitory concentration: > 20000 nM
Compound 4: a limit, no number; the forecaster's own chance of this, stated with the estimate: 70%; the middle value lies beyond the limit too.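

In this assay, among these compounds, the new compound gives the first step at the oxygen on the aromatic ring, with (4-methylphenyl)sulfonyl in place of hydrogen: an at least 1.6-fold higher number from compound 2 to compound 4 (0.20 log units; that floor lies within the scatter). Compound 4 is a limit, so only this floor can be read, and the true size of the change remains undetermined. On the aromatic carbon of the five-membered ring, 4-bromophenyl, pyridin-2-yl and 4-(trifluoromethyl)phenyl now all occur with the (4-methylphenyl)sulfonyl group, the steps among these three compounds cannot be read, and the series rests on a single limit: the limit of > 20000 nM in this assay, at which 3 of the 4 values shown sit.

As far as these compounds go, it remains open whether any group on that aromatic carbon brings a compound carrying (4-methylphenyl)sulfonyl off the limit, and whether 4-bromophenyl or pyridin-2-yl with hydrogen on the oxygen would return a number as compound 2 does. Also open, from the compounds shown here alone, is how an acetyl or a methyl on that oxygen, or an amine on the aryl ring, would read in this assay.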